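A Third Amine at the End of the Propyl Chain

The source may hold more compounds than are shown below. What is called first, only, known or untested is meant among the compounds shown, and "the series" means these compounds.

Measured so far in a functional assay on HT-29 cells (Homo sapiens) for cytotoxicity, read by MTT assay, with a stated time of 72 h; on this read-out lower numbers stand for stronger inhibition and higher numbers for weaker inhibition:
compound 1 `COc1cc2c(Oc3ccc(NC(=O)c4nnn(-c5ccccc5C(F)(F)F)c4C)cc3F)ccnc2cc1OCCCN1CCCC1` gives 200 nM
compound 2 `COc1cc2c(Oc3ccc(NC(=O)c4nnn(-c5ccccc5C(F)(F)F)c4C)cc3F)ccnc2cc1OCCCN1CCCCC1` gives 200 nM

Compound 2 stands level with compound 1 at the digits shown; the step of no change at the digits printed from compound 1 to compound 2 (within the scatter) lies within the scatter. Compound 3 `COc1cc2c(Oc3ccc(NC(=O)c4nnn(-c5ccccc5C(F)(F)F)c4C)cc3F)ccnc2cc1OCCCN1CCN(C)CC1` differs from compound 2 by 4-methylpiperazin-1-yl in place of piperidin-1-yl on a saturated chain carbon, three bonds along the chain from an oxygen on an aromatic ring. Among the compounds with values here, the only step that bears on this change is the one from compound 1 to compound 2, no change at the digits printed from compound 1 to compound 2 (within the scatter), so no step beyond the scatter is expected in this assay, that is no change at the digits printed from compound 2 to compound 3 (within the scatter). Compound 3 is therefore estimated at 200 nM, with a range from 90 nM to 500 nM.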

Compound 3, half-maximal inhibitory concentration: 230 nM
The estimate for compound 3 lay 1.2-fold (0.06 log units) below the measured number, within the range that was stated.
By their numbers in this assay, from the lowest: compounds 1, 2 and 3 (each within the scatter of the next).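

In this assay, 4-methylpiperazin-1-yl in place of piperidin-1-yl on this saturated chain carbon gives a 1.2-fold higher number from compound 2 to compound 3 (0.06 log units; within the scatter), and in place of pyrrolidin-1-yl it gives a 1.2-fold higher number from compound 1 to compound 3 (0.06 log units; within the scatter). The earlier compounds shown here carried only rings with 1 hetero atom at this position, whereas a six-membered non-aromatic ring with 2 hetero atoms now enters and all three compounds remain within the scatter of one another. Nothing given here accounts for this result. Still open, going by these compounds, is whether a morpholine ring, an open-chain dimethylamine or a carboxylic acid at this chain end would stay within that scatter. On these data alone, a longer chain carrying the same amines is equally open.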